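The source may report more compounds than this note shows. Statements on the series, on what has been measured and on what is new or still open speak of the compounds shown alone.

Measured so far in an ADME assay on HFF cells (Homo sapiens) for cytotoxicity, with a stated time of 8 days; on this read-out higher numbers stand for lower toxicity in this test and lower numbers for higher toxicity in this test:
Compound 1, `Nc1nc(NCc2ccccc2)c2ncn(/C=C3/CC3(CO)CO)c2n1`, gives > 300000 nM, which is a limit of the test rather than a number.
Compound 2, `CCCCCOc1nc(N)nc2c1ncn2/C=C1/CC1(CO)CO`, gives 259000 nM.
Compound 3, `CC(C)Sc1nc(N)nc2c1ncn2/C=C1/CC1(CO)CO`, gives > 300000 nM, again a limit and not a number.

Compound 3 therefore stands at the top of what this assay reports, alongside compound 1 (the limit of > 300000 nM in this assay, at which 2 of the 3 values shown sit). Compound 4, `CNc1nc(N)nc2c1ncn2/C=C1/CC1(CO)CO`, differs from compound 3 in one place: methylamino in place of isopropylsulfanyl on an aromatic carbon. Going by the values given here, two measured steps bear on this, both swapping the group on the same aromatic carbon: a step that the two limits leave unreadable from compound 1 to compound 3 and an at least 1.1-fold higher number from compound 2 to compound 3 (0.06 log units; that floor lies within the scatter), the latter within the scatter. Neither shows movement beyond the scatter, so the expected step is a number no higher from compound 3 to compound 4 (the limit leaves the size open). Compound 4 is estimated at 300000 nM, within 150000 nM to 600000 nM, most likely reported as a limit again.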

Compound 4, half-maximal cytotoxic concentration: 265000 nM
The estimate for compound 4 lay 1.1-fold (0.05 log units) above the measured number, and the stated range covers the measured number.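

With methylamino on this aromatic carbon, this assay gives a number rather than a limit, and the step is an at least 1.1-fold lower number from compound 3 to compound 4 (0.05 log units; that floor lies within the scatter) with isopropylsulfanyl leaving. The step is a 1.0-fold higher number from compound 2 to compound 4 (0.01 log units; within the scatter) with pentyloxy leaving, and an at least 1.1-fold lower number from compound 1 to compound 4 (0.05 log units; that floor lies within the scatter) with benzylamino leaving. None of these swaps on this carbon shows movement beyond the scatter, though the limit hides how far some steps run: the limit of > 300000 nM in this assay, at which 2 of the 4 values shown sit.

From the compounds shown here alone, how far compound 1 and compound 3 lie past that limit stays open. So does whether a carboxylic acid or a chlorine atom on this carbon would move the number beyond the scatter.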